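Swapping the amide substituent on a kinase inhibitor

A few compounds are considered here, and "the series" means these few. Any claim that something is new, unique, unknown or untested is made for them only; others in the source may bear on it.

Measured compounds:
Compound 1 `CNC(=O)c1ccncc1Nc1cc(-c2ccc3ccn(C)c3c2)c2nccnc2c1`: 83 nM
Compound 2 `CC(=O)N1CCCC(NC(=O)c2ccncc2Nc2cc(-c3ccc4ccn(C)c4c3)c3nccnc3c2)C1`: 11 nM

Both compounds share a core and differ only in the group carried on the amide-type nitrogen. In an assay for inhibition of 6-phosphofructo-2-kinase/fructose-2,6-bisphosphatase 3 (Homo sapiens), read by ADP-Glo, with a stated time of 2 h (a lower number here means a stronger inhibitor, a higher number a weaker inhibitor), compound 1 gives 83 nM, and compound 2 gives 11 nM, the lowest of the two numbers measured. Among the compounds with values here, the only step seen so far is a 7.5-fold lower number from compound 1 to compound 2 (0.88 log units; beyond the scatter), showing that a larger ring-bearing group on this nitrogen went with a stronger inhibitor.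

Compound 3 `Cn1ccc2ccc(-c3cc(Nc4cnccc4C(=O)NCC4COCCN4)cc4nccnc34)cc21` has not yet been measured. It differs from compound 2 by (morpholin-3-yl)methyl in place of 1-acetylpiperidin-3-yl on an amide-type nitrogen. The entering group is smaller than the one that leaves and carries a hydrogen-bond donor where the leaving group had none. Within the data shown here, no measured step covers this exact change; the single step from compound 1 to compound 2 suggests only that the group at this position matters. A moderate weakening is therefore expected, as a 2.3-fold higher number from compound 2 to compound 3 (0.36 log units; beyond the scatter). Compound 3 is estimated to give 25 nM in this assay, with a range from 8 nM to 80 nM.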

Compound 3, half-maximal inhibitory concentration: 33 nM
The estimate for compound 3 lay 1.3-fold (0.12 log units) below the measured number, and the stated range covers the measured number.
By their numbers in this assay, from the lowest: compound 2; then compound 3; then compound 1.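

Replacing 1-acetylpiperidin-3-yl with (morpholin-3-yl)methyl on the amide-type nitrogen gave a 3.0-fold higher number from compound 2 to compound 3 (0.48 log units; beyond the scatter), so the choice of ring-bearing group also matters, not only its presence. Set against the methyl of compound 1, the same group still gave a 2.5-fold lower number from compound 1 to compound 3 (0.40 log units; beyond the scatter), and two different ring-bearing groups now both go with a stronger inhibitor than methyl does. Nothing available explains why the three groups rank in this order.

The step from compound 2 to compound 3 changes the ring, the link to the nitrogen and the acetyl group all at once, so the compounds shown leave open which of these accounts for it. A (piperidin-3-yl)methyl group on this nitrogen would sit closer to both compounds and could begin to separate those parts.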